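The source may report more compounds than this note shows. Statements on the series, on what has been measured and on what is new or still open speak of the compounds shown alone.

Series notes. The shared core of compound 1 `CCCS(=O)(=O)Nc1ccc(F)c(C(=O)c2n[nH]c3ncc(-c4ccccc4)cc23)c1F` carries an unsubstituted phenyl; in an assay for binding affinity to dual specificity mitogen-activated protein kinase kinase 4 (Homo sapiens), read by KINOMEscan, tested at 100 nM (on this read-out higher numbers stand for a weaker effect at the one concentration tested and lower numbers for a stronger effect), compound 1 gives 2.4%. Among the compounds with values here, compound 2 `CCCS(=O)(=O)Nc1ccc(F)c(C(=O)c2n[nH]c3ncc(-c4cccc(Cl)c4)cc23)c1F` carries a 3-chlorophenyl instead, and in this assay compound 2 gives 40%, the highest of the two numbers measured so far. Within the data shown here, the one recorded step, a number 37.6 percentage points higher from compound 1 to compound 2 (beyond the scatter), shows that chloro in place of hydrogen on an aromatic carbon lifted the read-out far beyond the scatter. Compound 3 `CCCS(=O)(=O)Nc1ccc(F)c(C(=O)c2n[nH]c3ncc(-c4ccccc4OC)cc23)c1F` is not yet measured. It differs from compound 2 in one place: 2-methoxyphenyl in place of 3-chlorophenyl on an aromatic carbon. Among the measured compounds shown here, no measured step describes this exact exchange; the only step that bears on it is a number 37.6 percentage points higher from compound 1 to compound 2 (beyond the scatter), which shows that a single substituent on that aromatic ring can move the read-out strongly. Since compound 3 again carries a substituted phenyl, a read-out near compound 2 is expected rather than a return toward compound 1, although swapping one substituent for another leaves the direction open. The step of a number 5 percentage points lower from compound 2 to compound 3 (within the scatter) is expected to stay within the scatter. For compound 3 the estimate in this assay is 35%, with a range from 8% to 75%.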

Compound 3, a percentage reported as activity, at one concentration (the size of the read-out at that concentration, not a potency): 1.9%
Compound 3: middle estimate off by 33.1 percentage points, on the high side; measured number below the stated range.
By their numbers in this assay, from the lowest: compounds 3 and 1 (each within the scatter of the next); then compound 2.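

Compound 3 separates the effect of having a substituent on this phenyl from the effect of which substituent it is. Exchanging 3-chlorophenyl for 2-methoxyphenyl reverses the earlier rise in this assay (a number 38.1 percentage points lower from compound 2 to compound 3 (beyond the scatter)), while methoxy in place of hydrogen leaves the read-out unchanged (a number 0.5 percentage points lower from compound 1 to compound 3 (within the scatter)), in contrast to chloro in place of hydrogen (a number 37.6 percentage points higher from compound 1 to compound 2 (beyond the scatter)). A substituted phenyl at this place on the shared core is therefore compatible with a read-out level with that of the unsubstituted phenyl of compound 1, so the loss seen with compound 2 does not extend to both substituents shown here, and no measured property of these groups accounts for the difference between them.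

Chloro and methoxy differ both in the group and in where each sits on the phenyl, so these compounds cannot show which of the two matters; 2-chlorophenyl and 3-methoxyphenyl would separate them. As far as these compounds go, whether a larger group, such as a 2-ethoxyphenyl, or an amine on the same ring would keep the low read-out of compound 3 also remains open.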